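The source may report more compounds than this note shows. Statements on the series, on what has been measured and on what is new or still open speak of the compounds shown alone.

Measured compounds:
- compound 1 `COc1cccc(CNCCCNc2ccnc3cc(Oc4ccc(Cl)cc4)ccc23)c1O`: in an ADME assay for permeability, using PAMPA, with a stated time of 30 min, at pH 7.4 (a lower number here means that the compound crosses the layer more slowly, a higher number that the compound crosses the layer faster), compound 1 gives 317 10^-6 cm/s
- compound 2 `COc1cccc(CNCCCNc2ccnc3cc(CCC(C)C)ccc23)c1O`: in this assay compound 2 gives 23 10^-6 cm/s

For the measured compounds named here, compound 2 stands lowest of the two numbers; its only neighbour is compound 1, and the one measured step is a 14-fold lower number from compound 1 to compound 2 (1.14 log units; beyond the scatter). Compound 3 `COc1cccc(CNCCCNc2ccnc3cc(-c4ccccc4)ccc23)c1O` differs from compound 2 by phenyl in place of isopentyl on an aromatic carbon. The measured step ran the other way, a chain replacing a ring-bearing group and lowering the number; the present change puts a ring back, so a large rise in this assay is expected, though a ring on its own is not the same group. Compound 3 is estimated at 120 10^-6 cm/s, between 40 10^-6 cm/s and 350 10^-6 cm/s. The expected step is a 5.2-fold higher number from compound 2 to compound 3 (0.72 log units; beyond the scatter).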

Compound 3, apparent permeability: 237 10^-6 cm/s
Estimate against measurement, compound 3: 2.0-fold (0.30 log units) below, and the stated range covers the measured number.
By their numbers in this assay, from the lowest: compound 2; then compounds 3 and 1 (each within the scatter of the next).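

Putting phenyl in place of isopentyl on this aromatic carbon gives a 10-fold higher number from compound 2 to compound 3 (1.01 log units; beyond the scatter) in this assay, so a large change at this position does not need the oxygen link of compound 1. Putting phenyl in place of 4-chlorophenoxy gives a 1.3-fold lower number from compound 1 to compound 3 (0.13 log units; within the scatter) and so cannot be told apart, which leaves the isopentyl compound alone at the low end. No measurement shown here explains the difference. On these data alone, it stays open whether the aromatic ring itself matters, since a saturated ring such as cyclohexyl, or a pyridine ring, would separate ring type from chain.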